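Iodo in place of chloro, still unmeasured

The source may hold more compounds than are shown below. What is called first, only, known or untested is meant among the compounds shown, and "the series" means these compounds.

compound 1 `COC(=O)C1=C(C)N=C(C)/C(=C(\O)OC)C1c1ccccc1Cl` gives 2.19 nM
compound 2 `COC(=O)C1=C(C)NC(C)=C(C(=O)OC)C1c1ccccc1` gives 28.2 nM
compound 3 `COC(=O)C1=C(C)N=C(C)/C(=C(\O)OC)C1c1cccc(N(C)C)c1` gives 891 nM

All three values come from a functional assay (muscle tissue) with Cavia porcellus as the target; on this read-out lower numbers stand for an effect already at smaller amounts and higher numbers for an effect only at larger amounts of compound. Compound 1 stands lowest of the three, and its gaps to compound 2 and compound 3 both lie beyond the scatter.

Compound 4 `COC(=O)C1=C(C)N=C(C)/C(=C(\O)OC)C1c1ccccc1I` has not yet been measured. It differs from compound 1 in one place, with iodo in place of chloro on an aromatic carbon, turning 2-chlorophenyl into 2-iodophenyl (iodo in place of chloro on an aromatic carbon). The swap falls on a six-membered aromatic ring of carbon only, ortho to a large group.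

Among the compounds with values here, no two measured compounds differ in one place only, so the data offer no direct guide to this swap. The expectation therefore starts from compound 1 at 2.19 nM and allows a small move toward a higher number, not beyond the scatter. The expected step is a 1.8-fold higher number from compound 1 to compound 4 (0.26 log units; within the scatter). Compound 4 is estimated at 4 nM, with an expected range from 1.2 nM to 15 nM.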

Compound 4, half-maximal effective concentration: 46.8 nM
Estimate against measurement, compound 4: 12-fold (1.07 log units) below; measured number outside the range, above it.
By their numbers in this assay, from the lowest: compound 1; then compounds 2 and 4 (each within the scatter of the next); then compound 3.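

In this assay, iodo in place of chloro gives a 21-fold higher number from compound 1 to compound 4 (1.33 log units; beyond the scatter), so this place on the aromatic ring, ortho to a large group, does not treat the two halogens alike, even though one heavy atom replaces one heavy atom and the counted hydrogen-bond donors, acceptors and net charge stay the same. The earlier compounds shown here differed in more than one place and could not show that this single exchange, 2-chlorophenyl to 2-iodophenyl, moves the number so far on its own. Nothing measured here accounts for the size of this step.

On these data alone, whether bromo or fluoro at the same place would stay close to compound 1 or fall nearer compound 4 remains open. So does how a methyl or methoxy group there would read out on the same core.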